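A few compounds are considered here, and "the series" means these few. Any claim that something is new, unique, unknown or untested is made for them only; others in the source may bear on it.

In a functional assay on NCI-H2122 cells (Homo sapiens) for inhibition, read by microscopy, with a stated time of 10 days (a higher number here means a weaker inhibitor, a lower number a stronger inhibitor), compound 1 `Cc1nn(C)c2c1C(c1ccccc1)C(C#N)=C(N)O2` gives 9100 nM, compound 2 `Cc1nn(C)c2c1C(c1ccncc1)C(C#N)=C(N)O2` gives 4100 nM and compound 3 `Cn1nc(-c2ccccc2)c2c1OC(N)=C(C#N)C2c1ccncc1` gives 5200 nM. Compound 2 is framed by two steps: a 2.2-fold lower number from compound 1 to compound 2 (0.35 log units; beyond the scatter), and a 1.3-fold higher number from compound 2 to compound 3 (0.10 log units; within the scatter). Compound 4 `Cc1nn(C)c2c1C(c1cccnc1)C(C#N)=C(N)O2` carries pyridin-3-yl in place of pyridin-4-yl on a saturated ring carbon. The step made at that same carbon, a 2.2-fold lower number from compound 1 to compound 2 (0.35 log units; beyond the scatter), bears most directly and is modest, while the phenyl for methyl change on an aromatic carbon, a 1.3-fold higher number from compound 2 to compound 3 (0.10 log units; within the scatter), bears only weakly. Among the measured compounds shown here, no pyridin-3-yl compound has been measured, so no step beyond the scatter is expected in this assay. The expected change is a 1.2-fold higher number from compound 2 to compound 4 (0.09 log units; within the scatter). For compound 4 the estimated value is 5000 nM, within an expected range of 2500 nM to 9500 nM.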

Compound 4, half-maximal inhibitory concentration: 8800 nM
The estimate for compound 4 lay 1.8-fold (0.25 log units) below the measured number; measured number inside the range.
By their numbers in this assay, from the lowest: compounds 2, 3, 4 and 1 (each within the scatter of the next, the first and the last beyond it).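

At this saturated ring carbon, the site of the ring nitrogen counts in this assay: pyridin-3-yl in place of pyridin-4-yl gives a 2.1-fold higher number from compound 2 to compound 4 (0.33 log units; beyond the scatter) and is a modest step. Pyridin-3-yl in place of phenyl gives a 1.0-fold lower number from compound 1 to compound 4 (0.01 log units; within the scatter) and so offers no separation, which means the earlier step from phenyl holds for pyridin-4-yl but not for a ring nitrogen as such. No measurement available here accounts for this difference between the two pyridines. Still open, as far as these compounds go, is how pyridin-2-yl, or a phenyl carrying an amine or a methoxy group, would read at this carbon.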